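The source may hold more compounds than are shown below. What is called first, only, known or untested is meant among the compounds shown, and "the series" means these compounds.

Compound 1 `N#Cc1c(NCc2ccccc2)c(Cl)c2nc(N)nc(N)c2c1F` gives 0.3 ug/mL in a functional assay on HL-60 cells (Homo sapiens) for cytotoxicity, read by MTT assay; a higher number here means a weaker inhibitor, a lower number a stronger inhibitor. Compound 2 `N#Cc1c(NCc2ccccc2)c(F)c2nc(N)nc(N)c2c1F` gives 14 ug/mL in this assay, and compound 3 `N#Cc1c(NCc2ccccc2)c(Cl)c2nc(N)nc(N)c2c1NCc1ccccc1` gives 8.5 ug/mL in this assay. On the three numbers in hand compound 3 stands second highest; its closest companion is compound 2, a gap within the scatter, and its furthest is compound 1, reached by a 28-fold higher number from compound 1 to compound 3 (1.45 log units; beyond the scatter). The unmeasured compound 4 `N#Cc1c(NCc2ccccc2)c(F)c2nc(N)nc(N)c2c1NCc1ccccc1` differs from compound 3 by fluoro in place of chloro on an aromatic carbon. Among the measured compounds shown here, the one measured step of the same kind is a 47-fold higher number from compound 1 to compound 2 (1.67 log units; beyond the scatter), which was large and well beyond the scatter. That precedent is expected to carry over, so the step of a 5.9-fold higher number from compound 3 to compound 4 (0.77 log units; beyond the scatter) in this assay is expected to be upward and large. Whether the full size of that precedent repeats from a starting point that is already far from compound 1 is not shown by the numbers in hand, and the expected range is widened accordingly. Compound 4 is therefore estimated at 50 ug/mL in this assay, with a range from 12 ug/mL to 200 ug/mL.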

Compound 4, half-maximal inhibitory concentration: 7.2 ug/mL
For compound 4 the middle estimate is 6.9-fold (0.84 log units) above the measured one; the measured number lies below the stated range.
By their numbers in this assay, from the lowest: compound 1; then compounds 4, 3 and 2 (each within the scatter of the next).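

The effect of fluoro in place of chloro at this position depends on the group para to it: with a benzylamino group there, the change gives a 1.2-fold lower number from compound 3 to compound 4 (0.07 log units; within the scatter), and it does not reproduce the earlier step: the same change on two cores in this assay, a 47-fold higher number (1.67 log units; beyond the scatter) from compound 1 to compound 2 and a 1.2-fold lower number (0.07 log units; within the scatter) from compound 3 to compound 4, 55-fold (1.74 log units) apart, beyond the scatter of two such steps. The second change shows the same dependence, giving a 1.9-fold lower number from compound 2 to compound 4 (0.29 log units; within the scatter) with fluoro at this position rather than chloro: the same change on two cores in this assay, a 28-fold higher number (1.45 log units; beyond the scatter) from compound 1 to compound 3 and a 1.9-fold lower number (0.29 log units; within the scatter) from compound 2 to compound 4, 55-fold (1.74 log units) apart, beyond the scatter of two such steps. In this assay, each change therefore has a large step only when made from compound 1, and once either is in place, the other adds nothing beyond the scatter.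

On these data alone, whether bromo or methyl at this position would keep a number as low as that of compound 1, at 0.3 ug/mL, remains open. So does the effect of a methylamino group in place of the para benzylamino group.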